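Working notes on the series: from compound 3 to compound 4

The source may hold more compounds than are shown below. What is called first, only, known or untested is meant among the compounds shown, and "the series" means these compounds.

Measured so far in a functional assay on PC-3 cells (Homo sapiens) for inhibition, read by MTT assay, with a stated time of 72 h; a higher number here means a weaker inhibitor, a lower number a stronger inhibitor:
compound 1, `Cc1ccc(Cn2cc(CSC(=S)N3CCN(C(=O)OCc4ccccc4)CC3)nn2)cc1` — compound 1 gives > 128000 nM
compound 2, `O=C(OCc1ccccc1)N1CCN(C(=S)SCc2cn(Cc3ccc(F)cc3)nn2)CC1` — compound 2 gives > 128000 nM
compound 3, `COc1cc(Cn2cc(CSC(=S)N3CCN(C(=O)OCc4ccccc4)CC3)nn2)cc(OC)c1OC` — compound 3 gives > 128000 nM

Each of these three entries is a limit of this assay and not a number. For compound 3 the value is only a limit, and the two other values shown are limits as well, so compound 3 cannot be placed against compound 1 or compound 2 on the numbers; the step that the two limits leave unreadable from compound 1 to compound 3 and the step that the two limits leave unreadable from compound 2 to compound 3 are both unreadable, as is a step that the two limits leave unreadable from compound 1 to compound 2. The one firm point is the limit of > 128000 nM in this assay, at which 3 of the 3 values shown sit.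

Compound 4, `COc1cc(Cn2cc(CSC(=S)N3CCN(C(=O)OC(C)(C)C)CC3)nn2)cc(OC)c1OC`, is still to be measured in this assay. It differs from compound 3 by tert-butyl in place of benzyl on an oxygen next to a carbonyl group. Among the compounds with values here, no measured step touches that place, so none of the three steps bears on it directly, and none of them has a readable size anyway. With all three values at the limit, the expectation for compound 4 is that this assay will again report a limit rather than a number, and the step that the limit leaves unreadable from compound 3 to compound 4 is estimated as no readable change. Compound 4 is expected at 150000 nM, between 30000 nM and 500000 nM.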

Compound 4, half-maximal inhibitory concentration: > 128000 nM
Compound 4 was reported as a limit (the forecaster's own chance of this, stated with the estimate: 75%); the middle value does not contradict the limit.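

In this assay compound 4 gives > 128000 nM, which is a limit and not a number. Within the data shown here, compound 3 also stands at a limit, so no step from compound 3 to compound 4 can be read. The one firm point is: the limit of > 128000 nM in this assay, at which 4 of the 4 values shown sit.

The compounds shown leave open how strongly any of them inhibits in this assay, and whether benzyl or tert-butyl matters there.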